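Rearranging the basic side chain of compound 3

The source may report more compounds than this note shows. Statements on the series, on what has been measured and on what is new or still open speak of the compounds shown alone.

Compound 1 `NCCCNc1cc(N2CCc3ccccc3C2)nc2ccccc12` gives 8400 nM in an ADME assay on HEp-2 cells (Homo sapiens) for cytotoxicity, read by CCK-8 assay, with a stated time of 5 days; on this read-out lower numbers stand for higher toxicity in this test and higher numbers for lower toxicity in this test. Compound 2 `N=C(N)NCCNc1cc(N2CCc3ccccc3C2)nc2ccccc12` reaches only the limit of > 100000 nM, which is a limit and not a number. The change an at least 11-fold higher number from compound 1 to compound 2 (1.07 log units; beyond the scatter) is large. Compound 3 `Cc1ccc2nc(N3CCCc4ccc(F)cc4C3)cc(NCCN(C)C)c2c1` gives 89000 nM, the highest of the two numbers shown, with compound 1 nearest. Compound 4 `Cc1ccc2nc(N3CCCc4ccc(F)cc4C3)cc(NC(C)(C)CN)c2c1` differs from compound 3 by 1-(aminomethyl)-1-methylethyl in place of 2-(dimethylamino)ethyl on a nitrogen on an aromatic ring, a rearrangement of the same atoms. Among the measured compounds shown here, only the step from compound 1 to compound 2 touches this chain, and it alters the chain end rather than its branching, so it bears only loosely. A moderate step downward is expected, a 2.2-fold lower number from compound 3 to compound 4 (0.35 log units; beyond the scatter). Compound 4 is therefore estimated at 40000 nM, between 12000 nM and 100000 nM.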

Compound 4, half-maximal cytotoxic concentration: 25000 nM
Estimate against measurement, compound 4: 1.6-fold (0.20 log units) above, within the range that was stated.
By their numbers in this assay, from the lowest: compound 1; then compound 4; then compound 3. At a limit, above all of these: compound 2.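

In this assay, the atoms of the chain stay the same and only their arrangement changes, yet 1-(aminomethyl)-1-methylethyl in place of 2-(dimethylamino)ethyl gives a 3.6-fold lower number from compound 3 to compound 4 (0.55 log units; beyond the scatter). So at this position the number depends on how these atoms are joined, not only on which atoms are present. No measurement shown here explains the shift.

The change combines a branched chain with a free amine at its end, and the compounds shown do not separate the two. As far as these compounds go, a straight 2-aminoethyl chain on the same core would test the branching, while the effect of a longer chain also remains open.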